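The compounds below may be only part of what the source reports. "The series", "measured", "known", "first", "only" and "open" are said of these compounds alone.

Measured compounds:
compound 1, `CC(=O)OCC(CCn1cc(C#Cc2ccc(Br)cc2)c(=O)n(C(=O)c2ccccc2)c1=O)COC(C)=O` — in a functional assay on SW-620 cells (Homo sapiens) for antiproliferative activity, read by MTT assay, with a stated time of 72 h (on this read-out lower numbers stand for stronger inhibition and higher numbers for weaker inhibition), compound 1 gives > 100000 nM, a limit of the assay.
compound 2, `O=c1[nH]c(=O)n(CCC(CO)CO)cc1C#Cc1cc(F)cc(F)c1` — in this assay compound 2 gives > 100000 nM, a limit.
compound 3, `O=c1[nH]c(=O)n(CCC(CO)CO)cc1C#Cc1ccc(Br)cc1` — in this assay compound 3 gives > 100000 nM, a limit.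

Compound 3 stands at the assay limit, where all three values shown sit: the limit of > 100000 nM in this assay, at which 3 of the 3 values shown sit. Going by the values given here, the single one-place step, a step that the two limits leave unreadable from compound 2 to compound 3, cannot be read: both its ends are limits. Compound 4, `CCCCCc1ccc(C#Cc2cn(CCC(CO)CO)c(=O)[nH]c2=O)cc1`, differs from compound 3 by pentyl in place of bromo on an aromatic carbon. Among the compounds with values here, no measured step bears on this change, so no direction beyond the scatter can be drawn from the numbers. Compound 4 is therefore expected to stay near the limit, estimated at 150000 nM with a range from 20000 nM to 1000000 nM. The expected step that the limit leaves unreadable from compound 3 to compound 4 is thus no change beyond the scatter.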

Compound 4, half-maximal inhibitory concentration: > 100000 nM
Compound 4: a limit, no number; the forecaster's own chance of this, stated with the estimate: 70%; the middle value lies beyond the limit too.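

The step between compound 3 and compound 4 cannot be read, as both values are limits and not numbers: the limit of > 100000 nM in this assay, at which 4 of the 4 values shown sit.

The compounds shown leave open whether pentyl or bromo on the aromatic carbon makes any difference in this assay.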